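Chloro for bromo in a series at its limit

This account rests on a few compounds, and the source may have more. Where it says the series, first, only, none or still open, it means among the compounds named here.

In an ADME assay on Raji cells (Homo sapiens) for cytotoxicity, read by CellTiter-Glo and resazurin assay, with a stated time of 72 h (a higher number here means that more compound is needed for the effect, a lower number that less compound is needed), compound 3 `CC(C)N(Cc1cccc(OCCCCCC(=O)O)c1)C(=O)c1ccc(-c2cccc(Br)c2)cc1` gives > 26000 nM and this is a limit of the assay. Compound 1 `CC(C)N(Cc1cccc(OCCCCCC(=O)O)c1)C(=O)c1ccc(-c2cccc(-c3ccccc3)c2)cc1` gives > 26000 nM in this assay and this too is a limit. Compound 2 `CC(=O)c1cccc(-c2ccc(C(=O)N(Cc3cccc(OCCCCCC(=O)O)c3)C(C)C)cc2)c1` gives > 26000 nM in this assay and this is likewise a limit. The measured compounds therefore share one reading, the limit of > 26000 nM in this assay, at which 3 of the 3 values shown sit, and none of them offers a number.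

Compound 4 `CC(C)N(Cc1cccc(OCCCCCC(=O)O)c1)C(=O)c1ccc(-c2cccc(Cl)c2)cc1` departs from compound 3 in a single place: chloro in place of bromo on an aromatic carbon (chloro in place of bromo on an aromatic carbon, meta to a large group).

The measured steps that bear on this change are exchanges on an aromatic carbon of the same ring: a step that the two limits leave unreadable from compound 1 to compound 3 and a step that the two limits leave unreadable from compound 2 to compound 3 and also a step that the two limits leave unreadable from compound 1 to compound 2. None of them has a readable size. Still, phenyl, acetyl and bromo all give the same limit, so no step beyond the scatter is expected in this assay and no direction can be assigned. The expected step is a number no higher from compound 3 to compound 4 (the limit leaves the size open) and a report as a limit again is the likely outcome. For compound 4 the estimate is 26000 nM with an expected range from 15000 nM to 50000 nM in this assay.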

Compound 4, half-maximal effective concentration: > 21900 nM
Compound 4 was reported as a limit (the forecaster's own chance of this, stated with the estimate: 90%); the middle value lies beyond the limit too.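

In this assay compound 4 gives > 21900 nM, and this is a limit. Among the compounds shown here, compounds 1, 2 and 3 also stand at limits, so no step involving compound 4 can be read. The compounds shown leave open whether any group at this place on the shared core would give a readable number in this assay.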